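The source may report more compounds than this note shows. Statements on the series, on what has been measured and on what is new or still open speak of the compounds shown alone.

The study covers two measured compounds and one that has not yet been tested in a functional assay on HCT-116 cells (Homo sapiens) for inhibition, read by sulforhodamine B assay, with a stated time of 72 h; a lower number here means a stronger inhibitor, a higher number a weaker inhibitor. Compound 1 `COc1ccc2cc(C(C)c3nnc4n3N=C(c3ccc(Br)cc3)CS4)ccc2c1` is the starting point; in this assay compound 1 gives 11700 nM. The only other measured entry, compound 2 `CC(c1ccc(-c2ccccc2)c(F)c1)c1nnc2n1N=C(c1ccc(C(F)(F)F)cc1)CS2`, carries a different aryl group on the core and a different aryl on the side chain; in this assay compound 2 gives 6100 nM. The two values lie within the scatter of each other, so compound 1 and compound 2 cannot be told apart on these numbers, and nothing in the set so far separates a stronger from a weaker inhibitor.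

The next compound, compound 3 `COc1ccc2cc(C(C)c3nnc4n3N=C(c3ccc(C)cc3)CS4)ccc2c1`, keeps the whole of compound 1 apart from one point: methyl in place of bromo on an aromatic carbon. For the measured compounds named here, no pair of measured compounds shows this particular swap, so no step size is known for it. Both measured compounds sit at weak inhibition, and a single swap of one heavy atom for another on the aryl group gives no reason in these data to expect a move beyond the scatter. The step is expected to be a 1.2-fold higher number from compound 1 to compound 3 (0.08 log units; within the scatter), roughly flat. Compound 3 is therefore estimated at 14000 nM, within a range from 5500 nM to 40000 nM.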

Compound 3, half-maximal inhibitory concentration: 10200 nM
Compound 3: the middle estimate sits 1.4-fold (0.14 log units) above what was measured; measured number inside the range.
By their numbers in this assay, from the lowest: compounds 2, 3 and 1 (each within the scatter of the next).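

In this assay, for the compounds shown here, going from 4-bromophenyl to 4-methylphenyl gives a 1.1-fold lower number from compound 1 to compound 3 (0.06 log units; within the scatter), the first step in the set that changes one place only, since compound 1 and compound 2 differ in more than one. It shows that at this position, para to a large group, methyl and bromo cannot be told apart by this read-out, so exchanging one heavy atom for another, with no ring, hydrogen-bond donor, hydrogen-bond acceptor or net charge entering or leaving, does not separate compound 3 from compound 1. The data on hand offer no independent measurement that would account for this flat step.

One swap between two single-atom groups cannot show whether the number at this position can move at all, and an amine, a carboxylic acid or a longer chain in the same place would put that to a sharper test. The compounds shown also leave open whether the side chain of compound 1 matters more than this position, as no step yet isolates a change there.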